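Swapping benzamido for anilino on a shared core

The compounds below may be only part of what the source reports. "The series", "measured", "known", "first", "only" and "open" are said of these compounds alone.

Measured so far in an ADME assay on microsomes from liver (Homo sapiens) for metabolic stability, read by LC-MS, using NADPH, with stated times of 5 min and 30 min, tested at 1 uM (a higher number here means faster removal of the compound, a lower number slower removal), for two compounds:
Compound 1 (`O=C(Nc1cnc(NCc2c(F)ccc3c2CCO3)n2cnnc12)c1cccnc1`) gives < 3 mL.min-1.g-1 as a limit of the assay
Compound 2 (`O=C(Nc1cnc(NCc2c(F)ccc3c2CCO3)n2cnnc12)c1ccccc1`) gives 10 mL.min-1.g-1 as a measured number

Within the data shown here, compound 2 holds the only actual number so far. The value of compound 1 is a limit.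

Compound 3 (`Fc1ccc2c(c1CNc1ncc(Nc3ccccc3)c3nncn13)CCO2`) has not yet been measured. It differs from compound 2 by phenyl in place of benzoyl on a nitrogen on an aromatic ring (phenyl in place of benzoyl on a nitrogen on an aromatic ring, or benzamido to anilino).

Among the measured compounds shown here, only one measured step is available, and it bears on this change loosely. Taking an at least 3.3-fold higher number from compound 1 to compound 2 (0.52 log units; beyond the scatter) as the sole guide, with phenyl in place of pyridin-3-yl on a carbonyl carbon, a modest rise is expected in this assay even though no measured step removes a carbonyl. The expected step is a 2.0-fold higher number from compound 2 to compound 3 (0.30 log units; within the scatter) and it remains a rough estimate. For compound 3 the estimate is 20 mL.min-1.g-1 (expected range from 8 mL.min-1.g-1 to 50 mL.min-1.g-1).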

Compound 3, intrinsic clearance in microsomes: 20 mL.min-1.g-1
Compound 3: the middle estimate sits on the measured number at the digits printed, within the range that was stated.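

In this assay, the change from benzamido to anilino on this nitrogen gives a 2.0-fold higher number from compound 2 to compound 3 (0.30 log units; within the scatter), so compound 2 and compound 3 cannot be told apart, and the carbonyl can leave this position without a difference the assay resolves. The clear separation remains the one tied to pyridin-3-yl against phenyl, now also seen across the full change from (pyridin-3-yl)carbonyl to phenyl, which gives an at least 6.6-fold higher number from compound 1 to compound 3 (0.82 log units; beyond the scatter); both compounds that carry phenyl at this end stand beyond the scatter from compound 1. The true size of that gap is unknown because compound 1 rests on a limit of the assay: the limit of < 3 mL.min-1.g-1 in this assay, at which 1 of the 3 values shown sits.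

What remains open is whether the low number of compound 1 belongs to the pyridin-3-yl ring alone, since a pyridin-3-yl set directly on this nitrogen, without the carbonyl, is not among the compounds shown. Also open, from the compounds shown here alone, is how this position would respond to a group of another kind, such as a saturated amine or a carboxylic acid, and whether the parallel seen here holds on any other core.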